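The source may hold more compounds than are shown below. What is called first, only, known or untested is meant among the compounds shown, and "the series" means these compounds.

Measured in an ADME assay on CHO cells (Cricetulus griseus) for cytotoxicity, read by MTT assay; on this read-out lower numbers stand for higher toxicity in this test and higher numbers for lower toxicity in this test:
- compound 1 `NC1CCN(c2nccc3[nH]c(-c4cccc(OC(F)(F)F)c4)nc23)CC1`: 42000 nM
- compound 2 `CN1CCN(C2CCN(c3nccc4[nH]c(-c5cccc(OC(F)(F)F)c5)nc34)CC2)CC1`: 3000 nM
- compound 3 `CN1CCN(CC2CCN(c3nccc4[nH]c(-c5cccc(OC(F)(F)F)c5)nc34)CC2)CC1`: 950 nM

Compound 3 stands lowest of the three in this assay. The smallest gap to it is a 3.2-fold lower number from compound 2 to compound 3 (0.50 log units; beyond the scatter), and the widest is a 44-fold lower number from compound 1 to compound 3 (1.65 log units; beyond the scatter).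

Compound 4 `CN1CCN(CC2CCN(c3nccc4[nH]c(-c5cccc(C(=O)O)c5)nc34)CC2)CC1` is the next to be tested. It differs from compound 3 by carboxy in place of trifluoromethoxy on an aromatic carbon, meta to a large group: carboxy in place of trifluoromethoxy on an aromatic carbon.

Among the compounds with values here, no measured step touches this aromatic carbon. Every one, including a 14-fold lower number from compound 1 to compound 2 (1.15 log units; beyond the scatter), changes only the group on a saturated ring carbon. Within the data shown here, these steps therefore give a scale for how far the number can move, but no direct precedent. Among the measured compounds shown here, on that scale, a large move towards a higher number is expected, as a judgement with no measured step behind its direction.

The expected change is a 21-fold higher number from compound 3 to compound 4 (1.32 log units; beyond the scatter). Compound 4 is estimated at 20000 nM, with an expected range of 4000 nM to 100000 nM.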

Compound 4, half-maximal cytotoxic concentration: > 50000 nM
Compound 4: no number, only a limit; the forecaster's own chance of this, stated with the estimate: 35%; at least 2.5-fold (0.39 log units) between middle value and limit.
By their numbers in this assay, from the lowest: compound 3; then compound 2; then compound 1. At a limit, above all of these: compound 4.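

A change on this aromatic carbon alone, carboxy in place of trifluoromethoxy, gives an at least 52-fold higher number from compound 3 to compound 4 (1.72 log units; beyond the scatter), so the read-out in this assay responds to this position and not only to the group on the saturated ring carbon. For compound 4 the result of > 50000 nM is a limit of the assay and not a number. It is the only limit among the compounds shown: the limit of > 50000 nM in this assay, at which 1 of the 4 values shown sits.

With only these two groups compared on this aromatic carbon, the compounds shown cannot separate an effect particular to carboxy from what other replacements of trifluoromethoxy would do. As far as these compounds go, whether an amide or a methyl ester here would move the number as far, and whether carboxy would do the same alongside the amino group of compound 1, stays open.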